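This account rests on a few compounds, and the source may have more. Where it says the series, first, only, none or still open, it means among the compounds named here.

Measured so far in a functional assay on the whole organism (artery, strain albino) with Rattus norvegicus as the target, with a stated time of 900 min, at a dose of 10 mg/kg by the oral route; a lower number here means less inhibition, a higher number more inhibition at the dose given (going by the name of the read-out):

compound 1, `CC1=C(C(=O)Nc2ccc(Br)cc2)C(c2ccc(Cl)cc2Cl)N=C(SCc2ccccc2)N1`, gives 8.2%
compound 2, `CC1=C(C(=O)Nc2ccc([N+](=O)[O-])cc2)C(c2ccc(Br)cc2)N=C(SCc2ccccc2)N1`, gives 19.5%
compound 3, `CC1=C(C(=O)Nc2ccc([N+](=O)[O-])cc2)C(c2cccc([N+](=O)[O-])c2)N=C(SCc2ccccc2)N1`, gives 14.9%

Compound 3 stands second highest of the three numbers. Going by the values given here, its nearest neighbour is compound 2, and the one measured step, a number 4.6 percentage points lower from compound 2 to compound 3 (within the scatter), lies within the usual scatter. Compound 1 is the furthest away, yet that gap too lies within the scatter, so nothing in this set separates one compound from another beyond repeat variation.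

The next compound, compound 4, `CC1=C(C(=O)Nc2ccc([N+](=O)[O-])cc2)C(c2cccc([N+](=O)[O-])c2)N=C(SCc2cccc(Cl)c2)N1`, differs from compound 3 only at the benzylsulfanyl group: chloro in place of hydrogen on an aromatic carbon, that is, benzylsulfanyl to (3-chlorobenzyl)sulfanyl. Among the compounds with values here, no measured step bears on this part of the molecule. Within the data shown here, the only measured step, a number 4.6 percentage points lower from compound 2 to compound 3 (within the scatter), exchanged the aryl on the saturated ring carbon and stayed within the scatter, and the three compounds together show a narrow spread. There is therefore no ground to expect a step beyond the scatter in this assay for the new chloro.

Compound 4 is thus expected to give 15%, with a range from 4% to 27%. The step this estimate means is expected to be a number 0.1 percentage points higher from compound 3 to compound 4 (within the scatter).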

Compound 4, a percentage reported as inhibition, in the whole organism at one dose (the size of the read-out at that dose, not a potency): 10.8%
Beside the measured number, compound 4's estimate is 4.2 percentage points above it, and the stated range covers the measured number.
By their numbers in this assay, from the lowest: compounds 1, 4, 3 and 2 (each within the scatter of the next, the first and the last beyond it).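

Going by these compounds alone, at the benzylsulfanyl group, a part of the molecule no earlier pair had touched, chloro in place of hydrogen on an aromatic carbon gives in this assay a number 4.1 percentage points lower from compound 3 to compound 4 (within the scatter). For this pair, the change to (3-chlorobenzyl)sulfanyl therefore leaves compound 3 and compound 4 indistinguishable at this single oral dose, just as the exchange of the aryl on the saturated ring carbon gave no step beyond the scatter in the earlier pair, so neither of the two places changed so far has yet separated two compounds. No measured information is available to explain the result for this change.

Going by these compounds, it remains open whether a methoxy group or an amine on this aromatic ring, or a longer chain such as butyl in place of the benzyl, would give a step beyond the scatter. On these data alone, it is also open whether the same chloro would give a similar result with the 4-bromophenyl group of compound 2 on the saturated ring carbon, in place of the 3-nitrophenyl group carried by compound 3 and compound 4.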